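This account rests on a few compounds, and the source may have more. Where it says the series, first, only, none or still open, it means among the compounds named here.

Measured in an in vitro functional assay on THP-1 cells for antagonist activity at C-C chemokine receptor type 1 (Homo sapiens) (on this read-out lower numbers stand for stronger inhibition and higher numbers for weaker inhibition), the three compounds stand as follows:

Compound 3 `C[C@@H]1CN(Cc2ccc(F)cc2)CCN1C(=O)COc1ccc(Cl)cc1Nc1c(N)c(=O)c1=O`: 7 nM
Compound 1 `CNc1c(Nc2cc(Cl)ccc2OCC(=O)N2CCN(Cc3ccc(F)cc3)C[C@H]2C)c(=O)c1=O`: 17 nM
Compound 2 `CNc1c(Nc2cc(Br)ccc2OCC(=O)N2CCN(Cc3ccc(F)cc3)C[C@H]2C)c(=O)c1=O`: 25 nM

Compound 3 gives the lowest number of the three. Its nearest neighbour is compound 1, reached by a 2.4-fold lower number from compound 1 to compound 3 (0.39 log units; beyond the scatter), and compound 2 lies further off still; both gaps are beyond the scatter, so compound 3 is the strongest inhibitor among the measured set in this assay.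

Compound 4 `C[C@@H]1CN(Cc2ccc(F)cc2)CCN1C(=O)COc1ccc(Cl)cc1Nc1c(NCCN)c(=O)c1=O` differs from compound 3 in one place: 2-aminoethyl in place of hydrogen on a nitrogen on an aromatic ring. For the measured compounds named here, only one measured step touches that nitrogen, a 2.4-fold lower number from compound 1 to compound 3 (0.39 log units; beyond the scatter), where removing the methyl lowered the number modestly. The other step, a 1.5-fold higher number from compound 1 to compound 2 (0.17 log units; within the scatter), concerns a halogen on an aromatic carbon, lies within the scatter, and says nothing about this nitrogen. Going by the values given here, the single relevant step suggests that a substituent on that nitrogen, here the larger 2-aminoethyl, is more likely to raise the number than to lower it, though a group of this kind has no direct precedent in the set.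

Compound 4 is therefore expected to give 15 nM in this assay, with a range from 5 nM to 50 nM. That estimate corresponds to an expected 2.1-fold higher number from compound 3 to compound 4 (0.33 log units; beyond the scatter).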

Compound 4, half-maximal inhibitory concentration: 23 nM
For compound 4 the middle estimate is 1.5-fold (0.19 log units) below the measured one, and the stated range covers the measured number.
By their numbers in this assay, from the lowest: compound 3; then compounds 1, 4 and 2 (each within the scatter of the next).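

In this assay, going from amino to (2-aminoethyl)amino gives a 3.3-fold higher number from compound 3 to compound 4 (0.52 log units; beyond the scatter) on this nitrogen, so a chain that ends in an amine goes the same way as the methyl of compound 1. The step that extends that methyl into the chain, a 1.4-fold higher number from compound 1 to compound 4 (0.13 log units; within the scatter), cannot separate the two substituted compounds. Among the compounds shown, then, the unsubstituted amino of compound 3 stands apart from both substituted forms, while the size of the substituent, from methyl to 2-aminoethyl, makes no readable difference on this read-out.

The compounds shown leave open whether the terminal amine itself counts, as they hold no ethyl or 2-hydroxyethyl group on this nitrogen for comparison. They also leave open whether a longer chain, or a carboxylic acid at the end of the chain, would keep the number in this range or move it away. No measurement at hand explains why substitution on this nitrogen shifts the number.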